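The source may report more compounds than this note shows. Statements on the series, on what has been measured and on what is new or still open speak of the compounds shown alone.

Compound 1 `Cc1c(O)c(C)c2c(c1O)C(=O)CC(c1ccc(Cl)cc1)O2`: in a functional assay on HUVEC cells (Homo sapiens) (a higher number here means that more compound is needed for the effect, a lower number that less compound is needed), compound 1 gives > 50000 nM, which is a limit of the assay and not a number.
Compound 2 `Cc1c(O)c(C)c2c(c1O)C(=O)CC(c1ccccc1Cl)O2`: in this assay compound 2 gives > 20000 nM, again a limit of the assay.

Among the compounds with values here, compound 1 thus stands at a limit only, and the one further value shown is also a limit, so no order between the two can be read. Within the data shown here, the single measured step that the two limits leave unreadable from compound 1 to compound 2 cannot be sized, as the limit of > 20000 nM in this assay, at which 1 of the 2 values shown sits, and the limit of > 50000 nM in this assay, at which 1 of the 2 values shown sits, show. Compound 3 `COc1ccc(C2CC(=O)c3c(O)c(C)c(O)c(C)c3O2)cc1` differs from compound 1 by methoxy in place of chloro on an aromatic carbon. Among the measured compounds shown here, no measured step covers an exchange of this kind, and the one step available is unreadable, so for this assay no move beyond the scatter can be asserted in either direction; the expected step of a number no higher from compound 1 to compound 3 (the limit leaves the size open) is therefore set near zero. Compound 3 is accordingly estimated at 50000 nM, within 10000 nM to 200000 nM, and most probably the assay will again report only a limit.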

Compound 3, half-maximal effective concentration: "not active" (no number reported)
Nothing numeric was reported for compound 3; there is nothing to compare the estimate with.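

Compound 3 is reported as not active in this assay, without a number, so no new step can be read between compound 1 and compound 3. The compounds shown leave open how methoxy and chloro compare on the shared core in this assay.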